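Compound 1 to compound 4: one group replaced

A few compounds are considered here, and "the series" means these few. Any claim that something is new, unique, unknown or untested is made for them only; others in the source may bear on it.

compound 1 `Cc1ccccc1-c1nc(CN2CCC(C(=O)NCCCN3CCC(C)CC3)CC2)c(C)o1`: > 0.5 h, a limit
compound 2 `Cc1oc(-c2ccc(Cl)c(Cl)c2)nc1CN1CCC(C(=O)NCCCN2C[C@H](C)C[C@H](C)C2)CC1`: > 0.5 h, a limit
compound 3 `CC[C@@H]1C[C@H](CC)CN(CCCNC(=O)C2CCN(Cc3nc(-c4c(F)cccc4F)oc3C)CC2)C1`: 0.065 h

All three half-lives come from an ADME assay on microsomes from liver (Rattus norvegicus) for metabolic stability, read by LC-MS, using NADPH, at 37 degrees C; a lower number here means that the compound disappears faster, a higher number that the compound lasts longer. Compound 1 stands at a limit and not at a number: > 0.5 h. Compound 2 also gives only a limit: > 0.5 h. Together these two make up (the limit of > 0.5 h in this assay, at which 2 of the 3 values shown sit). Compound 3 gives a number, 0.065 h.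

Compound 4 `Cc1ccccc1-c1nc(CN2CCC(C(=O)NCCCN3CC4CCCC(C4)C3)CC2)c(C)o1` has not been measured. It differs from compound 1 in one group: a group of 9 heavy atoms (8 carbon, 1 nitrogen; one six-membered non-aromatic ring of carbon only, one six-membered non-aromatic ring with 1 hetero atom) in place of a group of 7 heavy atoms (6 carbon, 1 nitrogen; one six-membered non-aromatic ring with 1 hetero atom), on a saturated chain carbon, three bonds along the chain from an amide-type nitrogen. The 4-methylpiperidin-1-yl group leaves, and a group with one six-membered non-aromatic ring of carbon only and one six-membered non-aromatic ring with 1 hetero atom enters. The place is a saturated chain carbon, three bonds along the chain from an amide-type nitrogen.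

Within the data shown here, no measured pair differs in one place only, so the expectation is loose. The estimated step is a shortening, an at least 1.6-fold lower number from compound 1 to compound 4 (0.22 log units; that floor lies within the scatter), in this assay, and it may prove no larger than the usual scatter. The basis is compound 3 at 0.065 h, which shows that a short half-life can occur in this series. A reading at the limit remains possible for compound 4. For compound 4 the expected half-life is 0.3 h, with an estimated range of 0.08 h to 1 h.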

Compound 4, half-life: 0.123 h
The estimate for compound 4 lay 2.4-fold (0.39 log units) above the measured number; low and high end bracket the measured number.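

In this assay, the exchange of the 4-methylpiperidin-1-yl group for the two-ring group, on a saturated chain carbon, three bonds along the chain from an amide-type nitrogen, gives an at least 4.0-fold lower number from compound 1 to compound 4 (0.60 log units; beyond the scatter). This place therefore responds in this assay: with the rest of the structure held fixed, a change in this one group moves the half-life beyond the scatter, which compound 2 and compound 3 could not show, as each differs from compound 1 in more than one place. The size of the step is only a floor, because compound 1 stands at a limit: the limit of > 0.5 h in this assay, at which 2 of the 4 values shown sit.

The compounds shown do not separate the effect of the extra ring of carbon from that of the larger group as a whole, and a morpholine ring or an unsubstituted piperidine ring in this place would help to tell these apart. Going by these compounds, whether the same exchange shortens the half-life to a similar extent on the cores of compound 2 and compound 3 also stays open.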